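Hydroxy for methoxy on the dimethylamino-bearing member

The source may report more compounds than this note shows. Statements on the series, on what has been measured and on what is new or still open speak of the compounds shown alone.

Two compounds of the series have been run in a functional assay on CAKI-1 cells (Homo sapiens) for inhibition, read by sulforhodamine B assay, with a stated time of 48 h; on this read-out lower numbers stand for stronger inhibition of growth and higher numbers for weaker inhibition of growth. Compound 1 `Cc1cc(O)cc(-c2nn(CC#N)cc2-c2ccnc(-c3ccc(Oc4ccccc4)cc3)c2)c1` gives 5780 nM. Compound 2 `COc1cc(C)cc(-c2nn(CC#N)cc2-c2ccnc(-c3ccc(N(C)C)cc3)c2)c1` gives 18200 nM, the higher of the two numbers; the gap to compound 1 lies beyond the scatter. Compound 1 and compound 2 differ in more than one place, so no single step can be read from that pair.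

Compound 3 `Cc1cc(O)cc(-c2nn(CC#N)cc2-c2ccnc(-c3ccc(N(C)C)cc3)c2)c1` has not yet been measured in this assay. Against compound 2 the change is hydrogen in place of methyl on an oxygen on an aromatic ring. Among the compounds with values here, no measured pair carries this change alone, so neither its size nor its direction is known from the data.

Compound 3 is expected to give about 10000 nM, within the range 3500 nM to 30000 nM. The expected step is a 1.8-fold lower number from compound 2 to compound 3 (0.26 log units; within the scatter), a modest move toward a lower number, though an outcome within the scatter of compound 2 is not excluded.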

Compound 3, concentration for total growth inhibition: 16400 nM
Compound 3: the middle estimate sits 1.6-fold (0.21 log units) below what was measured; the measured number falls inside the stated range.
By their numbers in this assay, from the lowest: compound 1; then compounds 3 and 2 (each within the scatter of the next).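

In this assay, methoxy and hydroxy on the 3-methyl-5-substituted phenyl group cannot be told apart on the dimethylamino-bearing member (a 1.1-fold lower number from compound 2 to compound 3 (0.05 log units; within the scatter)), so at this oxygen the methyl adds nothing that the read-out resolves. Within the data shown here, compound 3 also gives the first single-place read at the other end of the molecule, where dimethylamino in place of phenoxy on an aromatic carbon carries a modest step beyond the scatter (a 2.8-fold higher number from compound 1 to compound 3 (0.45 log units; beyond the scatter)); of the two places in which compound 1 and compound 2 differ, this is the one that shows a step beyond the scatter. No measurement on hand explains either step.

Going by these compounds, whether the methoxy to hydroxy step stays this small on the phenoxy-bearing member remains open. Also open, on these data alone, is how an amine or a longer chain such as ethoxy would read on that oxygen-bearing carbon of the ring.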